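This account rests on a few compounds, and the source may have more. Where it says the series, first, only, none or still open, it means among the compounds named here.

Of the compounds shown here, three of a shared core have been measured in a functional assay on MCF7 cells (Homo sapiens) for cytotoxicity, read by MTT assay, with a stated time of 72 h; on this read-out lower numbers stand for stronger inhibition and higher numbers for weaker inhibition. Compound 1 `CN1[C@@H]2c3[nH]c4ccccc4c3C[C@H]1[C@H](C#N)N1[C@@H](CNC(=O)c3cccc(C(F)(F)F)c3)c3[nH]c4ccccc4c3C[C@@H]21` gives 110 nM. Compound 2 `COc1ccc(C(=O)NC[C@H]2c3[nH]c4ccccc4c3C[C@H]3[C@H]4c5[nH]c6ccccc6c5C[C@@H]([C@H](C#N)N23)N4C)cc1` gives 600 nM. Compound 3 `CN1[C@@H]2c3[nH]c4ccccc4c3C[C@H]1[C@H](C#N)N1[C@@H](CNC(=O)c3cccc4c3CCCC4)c3[nH]c4ccccc4c3C[C@@H]21` gives 4470 nM, the highest of the three numbers: compound 3 stands a 41-fold higher number from compound 1 to compound 3 (1.61 log units; beyond the scatter) and a 7.5-fold higher number from compound 2 to compound 3 (0.87 log units; beyond the scatter), both beyond the scatter, so it is the weakest of the measured set.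

Compound 4 `CN1[C@@H]2c3[nH]c4ccccc4c3C[C@H]1[C@H](C#N)N1[C@@H](CNC(=O)c3cc4ccccc4o3)c3[nH]c4ccccc4c3C[C@@H]21` differs from compound 3 in one place: 1-benzofuran-2-yl in place of 1,2,3,4-tetrahydronaphthalen-5-yl on a carbonyl carbon. The two steps that bear on this are the ones in which the 1,2,3,4-tetrahydronaphthalen-5-yl group arrived, a 41-fold higher number from compound 1 to compound 3 (1.61 log units; beyond the scatter) and a 7.5-fold higher number from compound 2 to compound 3 (0.87 log units; beyond the scatter). In both, a group containing only aromatic rings was exchanged for one carrying a six-membered non-aromatic ring, and the number rose. Compound 4 removes that non-aromatic ring again and puts a fully aromatic 1-benzofuran-2-yl group in its place, so a lower number, back toward the range of compound 1 and compound 2, is expected. The expected step is an 8.9-fold lower number from compound 3 to compound 4 (0.95 log units; beyond the scatter), beyond the scatter. For compound 4 the estimate in this assay is 500 nM, with a range from 150 nM to 2000 nM.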

Compound 4, half-maximal inhibitory concentration: 320 nM
For compound 4 the middle estimate is 1.6-fold (0.19 log units) above the measured one; the measured number falls inside the stated range.
By their numbers in this assay, from the lowest: compound 1; then compounds 4 and 2 (each within the scatter of the next); then compound 3.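

Exchanging 1,2,3,4-tetrahydronaphthalen-5-yl for 1-benzofuran-2-yl on the carbonyl carbon gives a 14-fold lower number from compound 3 to compound 4 (1.15 log units; beyond the scatter) in this assay, so the high number of compound 3 is not a feature of the shared core and can be reversed by a change at this one position. This position also tolerates a two-ring group containing a five-membered aromatic ring with an oxygen atom, not only the single rings of the other compounds: a 1.9-fold lower number from compound 2 to compound 4 (0.27 log units; within the scatter) lies within the scatter, so 1-benzofuran-2-yl and 4-methoxyphenyl cannot be told apart here. The 3-(trifluoromethyl)phenyl group still keeps its lead, with a 2.9-fold higher number from compound 1 to compound 4 (0.46 log units; beyond the scatter), so among the groups made up only of aromatic rings the choice of group still matters.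

Nothing available here gives a reason for any of these differences. The compounds shown leave open what happens with sulfur in place of the oxygen, as in 1-benzothiophen-2-yl, or with an amine or a carboxylic acid on the ring.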